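This account rests on a few compounds, and the source may have more. Where it says the series, first, only, none or still open, it means among the compounds named here.

Measured so far:
Compound 1, `c1ccc(N2CCN(CCCCOc3ccc4c(c3)CCC4)CC2)cc1`, 50% in a functional assay on the whole organism for inhibition, with Mus musculus as the target, at a dose of 25 mg/kg by the oral route; on this read-out higher numbers stand for more inhibition at the one dose given (going by the name of the read-out) and lower numbers for less inhibition.
Compound 2, `Fc1cc2c(cc1OCCCCN1CCN(c3ccccc3)CC1)CCC2`, 79% in this assay.
Compound 3, `O=[N+]([O-])c1cc2c(cc1OCCCN1CCN(c3ccccc3)CC1)CCC2`, 24% in this assay.

Among the measured compounds shown here, from compound 1 to compound 2 the one change is fluoro in place of hydrogen on an aromatic carbon and it gives a number 29 percentage points higher from compound 1 to compound 2 (beyond the scatter). Compound 3 sits lowest of the three numbers; against compound 1 and compound 2 its value is lower by more than the usual scatter in both cases, but the difference between the core of compound 3 and that of compound 1 is not broken down here.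

Compound 4, `O=[N+]([O-])c1cc2c(cc1OCCCN1CCN(c3ccc(F)cc3)CC1)CCC2`, is not yet measured. It differs from compound 3 by fluoro in place of hydrogen on an aromatic carbon. This is the same kind of change as that from compound 1 to compound 2, not the same: there the fluorine enters on a ring that is part of a fused or bridged system of two rings, ortho to a large group, meta and para to a fused ring; here it enters on a six-membered aromatic ring of carbon only, para to a large group.

Resting only on the one earlier step of a number 29 percentage points higher from compound 1 to compound 2 (beyond the scatter), made at a different place, the step from compound 3 to compound 4 in this assay is expected to be smaller and less certain, about a number 16 percentage points higher from compound 3 to compound 4 (beyond the scatter). Compound 4 is thus estimated at 40%, with a range from 15% to 65%.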

Compound 4, a percentage reported as inhibition, in the whole organism at one dose (the size of the read-out at that dose, not a potency): 28%
For compound 4 the middle estimate is 12 percentage points above the measured one; the range from low to high includes it.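

Fluoro in place of hydrogen on an aromatic carbon gives a number 4 percentage points higher from compound 3 to compound 4 (within the scatter) in this assay, so the gain seen with this change on the core of compound 1 does not carry over to compound 4. The two steps differ in size: the same change on two cores in this assay, a number 29 percentage points higher (beyond the scatter) from compound 1 to compound 2 and a number 4 percentage points higher (within the scatter) from compound 3 to compound 4, 25 percentage points apart, beyond the scatter of two such steps This does not show what sets them apart, since the pairs differ in both the core and the place of the fluorine, which in compound 4 sits on a six-membered aromatic ring of carbon only, para to a large group, and two pairs cannot separate these factors.

Among the compounds shown here, it remains open whether fluoro at that same place on the core of compound 1 would give a step closer to the one from compound 1 to compound 2 or to the one from compound 3 to compound 4. From the compounds shown here alone, it is also open whether a chloro or methoxy group at that place would behave as fluoro does on either core.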